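The compounds below may be only part of what the source reports. "The series", "measured", "known", "first", "only" and "open" are said of these compounds alone.

Two compounds on a shared core, compound 1 (`C[C@@H]1CN(c2nc(-c3cnn(C)c3)ncc2C#N)CCN1C(=O)C1CCC1`) and compound 2 (`C[C@@H]1CN(c2nc(-c3cnn(C)c3)ncc2C#N)CCN1C(=O)C1CC1`), have been tested in an ADME assay on microsomes from liver (Rattus norvegicus) for pharmacokinetics; a higher number here means faster removal of the compound, a lower number slower removal. Compound 1 gives < 36 mL/min/kg, which is a limit and not a number. Compound 2 gives < 36 mL/min/kg, which is also a limit. The picture so far is therefore (the limit of < 36 mL/min/kg in this assay, at which 2 of the 2 values shown sit), and compound 2 has no exact place on the scale.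

Compound 3 (`CC1CC1C(=O)N1CCN(c2nc(-c3cnn(C)c3)ncc2C#N)C[C@H]1C`) differs from compound 2 by a single change, (methyl in place of hydrogen on a saturated ring carbon). This turns cyclopropyl into 2-methylcyclopropyl.

Within the data shown here, the one measured step that bears on this change is a step that the two limits leave unreadable from compound 1 to compound 2. It concerns the same group on the carbonyl, but its size cannot be read, so it offers no measured size to carry over. No step beyond the usual scatter is therefore expected in this assay, and neither direction is favoured.

The expected step is a step that the limit leaves unreadable from compound 2 to compound 3, an estimate made against a limit. For compound 3 the estimated clearance is 30 mL/min/kg, with an expected range from 14 mL/min/kg to 60 mL/min/kg.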

Compound 3, clearance: < 36 mL/min/kg
Compound 3 was reported as a limit; the forecaster's own chance of this, stated with the estimate: 60%; the middle value lies beyond the limit too.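

In this assay compound 3 gives < 36 mL/min/kg and this is a limit, not a number. Among these compounds, no step among compound 1, compound 2 and compound 3 can be read, because all three stand at the same limit: the limit of < 36 mL/min/kg in this assay, at which 3 of the 3 values shown sit. The compounds shown leave open where each truly lies on the scale, and whether cyclobutyl, cyclopropyl and 2-methylcyclopropyl on the carbonyl differ at all.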